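Benzimidazole series: hydroxyphenyl replacing chlorophenyl at the limit

The source may report more compounds than this note shows. Statements on the series, on what has been measured and on what is new or still open speak of the compounds shown alone.

Compound 3 `CS(=O)(=O)c1ccc2nc(-c3ccc(-c4ccc(Cl)cc4)cc3)[nH]c2c1` stands at the limit of an assay on isolated protein for inhibition of acyl-CoA desaturase 1 (Rattus norvegicus); on this read-out higher numbers stand for weaker inhibition and lower numbers for stronger inhibition: its value of > 20000 nM is a limit of the assay, not a number. Compound 1 `N#Cc1ccc2nc(-c3ccc(-c4ccccc4F)cc3)[nH]c2c1` is likewise reported only as a limit, > 20000 nM. Compound 2 `NS(=O)(=O)c1ccc2nc(-c3ccc(-c4ccccc4F)cc3)[nH]c2c1` gives 343 nM in this assay. Among the measured compounds shown here, the one measured step, an at least 58-fold lower number from compound 1 to compound 2 (1.76 log units; beyond the scatter), changes the group on the shared core, not the outer ring, and so does not bear on the present change. The evidence the limit of > 20000 nM in this assay, at which 2 of the 3 values shown sit, shows how much of the set sits at the limit.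

Compound 4 `CS(=O)(=O)c1ccc2nc(-c3ccc(-c4ccccc4O)cc3)[nH]c2c1` differs from compound 3 by 2-hydroxyphenyl in place of 4-chlorophenyl on an aromatic carbon. For the measured compounds named here, no measured step covers this change; compound 2 carries a different group at the outer ring and a different group on the core, so it offers no single-point comparison. The step of an at least 2.0-fold lower number from compound 3 to compound 4 (0.30 log units; that floor lies within the scatter) is therefore expected to be modest and uncertain, with a fair chance that compound 4 again returns only a limit. Compound 4 is estimated at 10000 nM in this assay, in a range from 1500 nM to 40000 nM.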

Compound 4, half-maximal inhibitory concentration: 336 nM
For compound 4 the middle estimate is 30-fold (1.47 log units) above the measured one; measured number below the stated range.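

With the shared core held fixed, 2-hydroxyphenyl in place of 4-chlorophenyl gives an at least 59-fold lower number from compound 3 to compound 4 (1.77 log units; beyond the scatter) in this assay, so the outer ring can decide between a compound with a measurable value and one at the limit. The value of compound 3, > 20000 nM, is a limit of the assay and not a number, so the size of this step is a floor and not a measured gap. Some of the values shown remain limits: the limit of > 20000 nM in this assay, at which 2 of the 4 values shown sit.

The two outer rings differ both in the substituent and in where it sits, so the compounds shown do not separate the hydroxyl from its place on the ring. Going by these compounds, a 4-hydroxyphenyl, 2-chlorophenyl, 2-methoxyphenyl or 2-aminophenyl group on the same core would address this, and whether the gain carries over to the core of compound 2 also remains open.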